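Replacing the Ester with a Hydroxymethyl on the Chain

The compounds below may be only part of what the source reports. "The series", "measured", "known", "first", "only" and "open" are said of these compounds alone.

Measured compounds:
compound 1 `O=C(O)COc1cccc(/C=C\c2nc(-c3ccccc3)c(-c3ccccc3)o2)c1` gives 180 nM
compound 2 `CCOC(=O)C(Cc1cccc(OCC(=O)O)c1)c1nc(-c2ccccc2)c(-c2ccccc2)o1` gives 120 nM
compound 3 `CCOC(=O)C(Cc1cccc(OCC(=O)O)c1OC)c1nc(-c2ccccc2)c(-c2ccccc2)o1` gives 1180 nM

In a functional assay for inhibition, with Homo sapiens as the target (a lower number here means a stronger inhibitor, a higher number a weaker inhibitor), compound 2 gives 120 nM, the lowest of the three numbers. Compound 1 sits at 180 nM, within the scatter of compound 2. Compound 3 sits at 1180 nM, beyond the scatter. For the measured compounds named here, the only step between single-change neighbours is a 9.8-fold higher number from compound 2 to compound 3 (0.99 log units; beyond the scatter), which concerns a different part of the molecule. Compound 4 `O=C(O)COc1cccc(CC(CO)c2nc(-c3ccccc3)c(-c3ccccc3)o2)c1` differs from compound 2 in one place: hydroxymethyl in place of ethoxycarbonyl on a saturated chain carbon bound to an aromatic carbon and a saturated chain carbon. Going by the values given here, no measured step touches this chain position, so only a modest change in either direction is expected, a 2.1-fold higher number from compound 2 to compound 4 (0.32 log units; beyond the scatter). For compound 4 the estimate in this assay is 250 nM, within the range 80 nM to 800 nM.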

Compound 4, half-maximal inhibitory concentration: 9310 nM
Compound 4: middle estimate off by 37-fold (1.57 log units), on the low side, outside the stated range (above it).
By their numbers in this assay, from the lowest: compounds 2 and 1 (each within the scatter of the next); then compound 3; then compound 4.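

In this assay, for the compounds shown here, hydroxymethyl in place of ethoxycarbonyl on this saturated chain carbon gives a 78-fold higher number from compound 2 to compound 4 (1.89 log units; beyond the scatter), so this chain position, which no earlier step touched, can shift the number strongly. The change swaps a larger group with no hydrogen-bond donor for a smaller one with a hydrogen-bond donor, and this single pair cannot separate those two differences. Nothing available explains why the number rises so far. Going by these compounds, whether any group other than ethoxycarbonyl suits this carbon remains open. A methyl ester, a carboxylic acid or a primary amide there would help show which feature of ethoxycarbonyl matters.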